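Methylthiourea versus cyanoguanidine on the shared core

The source may hold more compounds than are shown below. What is called first, only, known or untested is meant among the compounds shown, and "the series" means these compounds.

Two compounds of the series have numbers. Compound 1 `C/N=C(\S)NCCCCn1nc(-c2ccccc2)ccc1=O` gives 28.9 mg/kg in a functional assay on the whole organism (stomach) with Rattus norvegicus as the target; a higher number here means that more compound is needed for the effect, a lower number that less compound is needed. Compound 2 `CN(C)/C(=N/CCCn1nc(-c2ccccc2)ccc1=O)NC#N` gives 53 mg/kg in this assay, and the two values lie within the scatter of each other, so neither stands apart; the step of a 1.8-fold higher number from compound 1 to compound 2 (0.26 log units; within the scatter) is the only one recorded.

Compound 3 `C/N=C(\S)NCCCn1nc(-c2ccccc2)ccc1=O` is not yet measured. It differs from compound 2 by a group of 5 heavy atoms (2 carbon, 2 nitrogen, 1 sulfur; no ring) in place of a group of 8 heavy atoms (4 carbon, 4 nitrogen; no ring), on a saturated chain carbon, three bonds along the chain from an aromatic nitrogen. Among the compounds with values here, the entering group is the one that compound 1 carries, so the recorded step bears on this change in reverse: the exchange toward the cyanoguanidine from compound 1 to compound 2 moved the number only within the scatter, and the return to the methylthiourea in compound 3 is expected to move it no further than that, if anything slightly downward. The estimated step of a 1.8-fold lower number from compound 2 to compound 3 (0.25 log units; within the scatter) therefore stays within the scatter. Compound 3 is expected to give about 30 mg/kg in this assay, with the range 12 mg/kg to 75 mg/kg, because compound 1 with the same group gave 28.9 mg/kg.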

Compound 3, dose for half-maximal effect: > 100 mg/kg
Compound 3 was reported as a limit; the forecaster's own chance of this, stated with the estimate: 5%; middle value at least 3.3-fold (0.52 log units) from the limit.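

Compound 3 stands as a limit and not a number in this assay: the limit of > 100 mg/kg in this assay, at which 1 of the 3 values shown sits. Within the data shown here, with the methylthiourea kept, the group of 5 heavy atoms in place of the group of 6 heavy atoms gives an at least 3.4-fold higher number from compound 1 to compound 3 (0.53 log units; beyond the scatter), the first step beyond the scatter, so at this position, on a saturated chain carbon, the length of the chain carrying the methylthiourea counts for this read-out, which the earlier pair could not show, since its two compounds differ in both chain and end group. On the shorter chain, the exchange of the cyanoguanidine for the methylthiourea gives an at least 1.8-fold higher number from compound 2 to compound 3 (0.27 log units; that floor lies within the scatter); that floor lies within the scatter and has no upper bound, so the closeness of the two end groups in the earlier pair holds only across different chains and cannot be carried over to a single chain.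

As far as these compounds go, how far compound 3 lies past its limit stays open, and both new steps therefore remain floors rather than sizes. Also open, from the compounds shown here alone, is how the cyanoguanidine behaves on the chain of compound 1, and whether a longer chain or a primary amine at the chain end would keep the effect.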